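The source may hold more compounds than are shown below. What is called first, only, known or untested is meant among the compounds shown, and "the series" means these compounds.

Measured compounds:
Compound 1 `CC(C(=O)NCc1ccc(C(F)(F)F)nc1N(C)C)c1ccc(NS(C)(=O)=O)c(F)c1` — in a functional assay on CHO-K1 cells for antagonist activity at transient receptor potential cation channel subfamily V member 1 (Homo sapiens), read by FLIPR (on this read-out lower numbers stand for stronger inhibition and higher numbers for weaker inhibition), compound 1 gives 2390 nM.
Compound 2 `C[C@H](C(=O)NCc1ccc(C(F)(F)F)nc1N1CC[C@@H](OCc2ccccc2)C1)c1ccc(NS(C)(=O)=O)c(F)c1` — in this assay compound 2 gives 50 nM.
Compound 3 `CC(C(=O)NCc1ccc(C(F)(F)F)nc1N1CCC(Cc2ccc(F)c(F)c2)CC1)c1ccc(NS(C)(=O)=O)c(F)c1` — in this assay compound 3 gives 30 nM.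

Compound 1 stands highest of the three numbers, which means it is the weakest inhibitor among them. Compound 2, its nearest neighbour, gives a far lower number, and compound 3 lies further still, both beyond the usual scatter of repeated measurements.

Compound 4 `CC(C(=O)NCc1ccc(C(F)(F)F)nc1N1CCC(CN(C)C)CC1)c1ccc(NS(C)(=O)=O)c(F)c1` has not yet been measured. It differs from compound 1 in one place: 4-((dimethylamino)methyl)piperidin-1-yl in place of dimethylamino on an aromatic carbon. The small dimethylamino group on the aromatic carbon of the shared core is exchanged for a larger, ring-bearing group.

For the measured compounds named here, no direct step between measured compounds isolates such a change, so any expectation rests on what compound 2 and compound 3 show: both carry larger groups at this position and both give much lower numbers than compound 1. A step down, large and beyond the scatter, is therefore expected for compound 4, of about a 16-fold lower number from compound 1 to compound 4 (1.20 log units; beyond the scatter). The estimate for compound 4 in this assay is 150 nM, within a range from 40 nM to 600 nM.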

Compound 4, half-maximal inhibitory concentration: 426 nM
Beside the measured number, compound 4's estimate is 2.8-fold (0.45 log units) below it; the measured number falls inside the stated range.
By their numbers in this assay, from the lowest: compounds 3 and 2 (each within the scatter of the next); then compound 4; then compound 1.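

In this assay the exchange of dimethylamino for 4-((dimethylamino)methyl)piperidin-1-yl gives a 5.6-fold lower number from compound 1 to compound 4 (0.75 log units; beyond the scatter) and so shows that a lower number at this position does not need an aromatic ring at the far end of the new group. That far end still counts: with the six-membered non-aromatic ring kept, dimethylamino in place of 3,4-difluorophenyl gives a 14-fold higher number from compound 3 to compound 4 (1.15 log units; beyond the scatter) and so shows that the ring alone does not reach the number of compound 3. Nothing measured here explains the size of either step.

Still open, from the compounds shown here alone, is whether an unsubstituted phenyl or a carboxylic acid at the far end would give a number closer to that of compound 3 or of compound 4. The effect of a longer chain carrying the dimethylamino group is also unknown.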